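Halogenated aryl on the triazole of the shared core

The compounds below may be only part of what the source reports. "The series", "measured", "known", "first", "only" and "open" are said of these compounds alone.

Compound 2, `Cc1ccc(-n2nncc2CN2C(=O)C3(C(C#N)=C(N)Oc4c3c3nc5ccccc5nc3c3ccccc43)c3ccccc32)cc1C`, is known in a functional assay on HepG2 cells (Homo sapiens) for antiproliferative activity, read by MTT assay, with a stated time of 48 h (a higher number here means a weaker inhibitor, a lower number a stronger inhibitor), only as a limit of the assay: in this assay compound 2 gives > 50000 nM. Its only measured relative, compound 1, `COc1ccccc1-n1nncc1CN1C(=O)C2(C(C#N)=C(N)Oc3c2c2nc4ccccc4nc2c2ccccc32)c2ccccc21`, is likewise known only as a limit, and in this assay compound 1 gives > 50000 nM. For the measured compounds named here, the one measured step, a step that the two limits leave unreadable from compound 1 to compound 2, therefore has no readable size or direction; the limit of > 50000 nM in this assay, at which 2 of the 2 values shown sit, describes where both values sit.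

The unmeasured compound 3, `N#CC1=C(N)Oc2c(c3nc4ccccc4nc3c3ccccc23)C12C(=O)N(Cc1cnnn1-c1ccc(F)c(Cl)c1)c1ccccc12`, differs from compound 2 by 3-chloro-4-fluorophenyl in place of 3,4-dimethylphenyl on an aromatic nitrogen. Going by the values given here, the single step on record changes the same aromatic nitrogen substituent, but with both of its ends at a limit it offers no usable size. No shift beyond the scatter can be anticipated in this assay in either direction, and a further limit is the most probable outcome. Compound 3 is accordingly estimated at 60000 nM, within 25000 nM to 150000 nM. This corresponds to an expected step that the limit leaves unreadable from compound 2 to compound 3.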

Compound 3, half-maximal inhibitory concentration: > 50000 nM
Compound 3 was reported as a limit (the forecaster's own chance of this, stated with the estimate: 75%); the middle value does not contradict the limit.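

For the compounds shown here, no step among compound 1, compound 2 and compound 3 can be read in this assay, because all three are known there only as limits: the limit of > 50000 nM in this assay, at which 3 of the 3 values shown sit. The compounds shown leave open whether any substituent on the aromatic nitrogen gives a measurable antiproliferative value.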